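The source may hold more compounds than are shown below. What is called first, only, known or untested is meant among the compounds shown, and "the series" means these compounds.

Working notes on the series. The shared core of compound 1 `CCC[C@]1(C(=O)N2CC[C@](c3ccc(C(F)(C(F)(F)F)C(F)(F)F)cc3)(S(=O)(=O)c3ccc(F)cc3)C2)CC[C@H](C(=O)O)CC1` carries the acid-bearing ring that is the point of variation. In an ADME assay on microsomes from liver (Homo sapiens) for metabolic stability, with a stated time of 10 min (on this read-out higher numbers stand for a more stable compound and lower numbers for a less stable compound), compound 1 gives "not determined" (no result reported), so no number stands for it. Compound 3 `COC(=O)[C@H]1CC[C@H](C(=O)N2CC[C@](c3ccc(C(F)(C(F)(F)F)C(F)(F)F)cc3)(S(=O)(=O)c3ccc(F)cc3)C2)CC1` likewise gives "not determined" (no result reported) in this assay. For the measured compounds named here, compound 2 `O=C([C@H]1CC[C@H](c2nnn[nH]2)CC1)N1CC[C@](c2ccc(C(F)(C(F)(F)F)C(F)(F)F)cc2)(S(=O)(=O)c2ccc(F)cc2)C1` is the one member of the series with a number: in this assay compound 2 gives 100%, the whole of the compound remaining at the stated time.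

Compound 4 `O=C(N1CC[C@](c2ccc(C(F)(C(F)(F)F)C(F)(F)F)cc2)(S(=O)(=O)c2ccc(F)cc2)C1)C1(F)CCS(=O)(=O)CC1` differs from compound 1 as follows: 4-fluoro-1,1-dioxothian-4-yl in place of 4-carboxy-1-propylcyclohexyl on a carbonyl carbon. Going by the values given here, no step between two measured compounds is known, so the size of the change in this assay on going from compound 1 to compound 4 cannot be read from the data; the only anchor is the single value of compound 2 on the same core, and a reading within the scatter of that value is the plain expectation. For compound 4 the remaining fraction in this assay is estimated at 85%, with a range from 60% to 100%.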

Compound 4, percent of the compound remaining: 100%
The estimate for compound 4 lay 15 percentage points below the measured number, within the range that was stated.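

In this assay, replacing the 4-(1H-tetrazol-5-yl)cyclohexyl group with 4-fluoro-1,1-dioxothian-4-yl on a carbonyl carbon gives no change at the digits printed from compound 2 to compound 4 (within the scatter). For the compounds shown here, this is the first readable step at this position, and it shows that the read-out is kept with a different ring that has a hetero atom and carries fluorine, so the value of compound 2 is not unique to the tetrazole-bearing group. Nothing at hand accounts for this result or ties it to any property of either group.

Steps involving compound 1 or compound 3 cannot be read, as neither has a single number, so the effect of the carboxylic acid and its methyl ester remains unknown. Also open, as far as these compounds go, is what an amine or a simple unsubstituted cyclohexyl group would give on the same carbonyl carbon.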